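Swapping Cyclohexyl for Pyridin-3-yloxy on a Shared Core

The compounds below may be only part of what the source reports. "The series", "measured", "known", "first", "only" and "open" are said of these compounds alone.

Of the compounds shown here, three have been measured in a functional assay on KOPN-8 cells (Homo sapiens) for antiproliferative activity, with a stated time of 72 h; on this read-out higher numbers stand for an effect only at larger amounts of compound and lower numbers for an effect already at smaller amounts. Compound 1 `COc1ccc(-c2cc(=O)c3c(OC)cc(OC)cc3n2S(=O)(=O)c2ccc(C)c([N+](=O)[O-])c2)cc1` and compound 2 `COc1ccc(-c2cc(=O)c3c(OC)cc(OC)cc3n2S(=O)(=O)c2ccc(Cl)cc2)cc1` carry a sulfonyl-bound aryl group on their core, while compound 3 `COc1cc(OC)c2c(=O)cc(C(=O)Nc3ccc(C4CCCCC4)cc3)[nH]c2c1` carries an amide instead. For compound 1 this assay reports only a limit, > 51700 nM. For compound 2 it likewise reports only a limit, > 34400 nM. The step between them, a step that the two limits leave unreadable from compound 1 to compound 2, is therefore not readable. Going by the values given here, compound 3 gives 18400 nM, the only actual number among the three values.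

Compound 4 `COc1cc(OC)c2c(=O)cc(C(=O)Nc3ccc(Oc4cccnc4)cc3)[nH]c2c1` differs from compound 3 in a single place: (pyridin-3-yl)oxy in place of cyclohexyl on an aromatic carbon. Among the compounds with values here, no measured step involves this kind of change, and the one step that exists cannot be read, so there is no measured guidance for its size or direction. Compound 4 is therefore expected to give roughly 15000 nM, with a range from 4000 nM to 50000 nM. The expected step, a 1.2-fold lower number from compound 3 to compound 4 (0.09 log units; within the scatter), is estimated to stay within the usual scatter.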

Compound 4, half-maximal effective concentration: > 32100 nM
Compound 4 gave a limit, no number; the forecaster's own chance of this, stated with the estimate: 30%; middle value at least 2.1-fold (0.33 log units) from the limit.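

Going by these compounds alone, the first readable step in this assay concerns the aromatic carbon para to a large group: (pyridin-3-yl)oxy in place of cyclohexyl gives an at least 1.7-fold higher number from compound 3 to compound 4 (0.24 log units; that floor lies within the scatter). That floor stays within the usual scatter, so a real loss is not established, but the swap also brings no lower number, even with the added ring nitrogen and ether oxygen. The value for compound 4 is a limit and not a number: the limit of > 32100 nM in this assay, at which 1 of the 4 values shown sits.

From the compounds shown here alone, how far compound 4 truly lies from compound 3 remains open, and the step between the two sulfonyl compounds, each known only by a limit, cannot be read. Also open, going by these compounds, is whether an amine, a carboxylic acid or a longer chain on this same aromatic carbon would give a lower number than cyclohexyl does.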